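Second methyl on the 2-methylphenyl group of compound 3

A few compounds are considered here, and "the series" means these few. Any claim that something is new, unique, unknown or untested is made for them only; others in the source may bear on it.

compound 1 `O=C(/C=C/c1cccnc1)NCCCCCCCc1ccc(S(=O)(=O)Nc2ccccc2)cc1` gives 56.5 nM
compound 2 `Cc1ccc(NS(=O)(=O)c2cccc(CCCCCCNC(=O)/C=C/c3cccnc3)c2)cc1` gives 2.98 nM
compound 3 `Cc1ccccc1NS(=O)(=O)c1cccc(CCCCCCNC(=O)/C=C/c2cccnc2)c1` gives 0.456 nM

All three values come from a functional assay on K562 cells (Homo sapiens) for inhibition, read by CCK-8 assay, with a stated time of 72 h (on this read-out lower numbers stand for stronger inhibition and higher numbers for weaker inhibition), and compound 3 has the lowest number of the set. Compound 4 `Cc1ccc(C)c(NS(=O)(=O)c2cccc(CCCCCCNC(=O)/C=C/c3cccnc3)c2)c1` differs from compound 3 by methyl in place of hydrogen on an aromatic carbon in the change of 2-methylphenyl to 2,5-dimethylphenyl. Among the measured compounds shown here, the one measured step on this group is a 6.5-fold lower number from compound 2 to compound 3 (0.82 log units; beyond the scatter) with 2-methylphenyl in place of 4-methylphenyl. For the measured compounds named here, that step moved a methyl and added none, so it sets no firm direction, and no measured compound carries two methyl groups on this ring. A small rise is expected in this assay as a 1.5-fold higher number from compound 3 to compound 4 (0.19 log units; within the scatter) and it may stay within the scatter. For compound 4 the estimate is 0.7 nM with an expected range from 0.2 nM to 2.5 nM in repeat measurements.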

Compound 4, half-maximal inhibitory concentration: 0.84 nM
For compound 4 the middle estimate is 1.2-fold (0.08 log units) below the measured one; the measured number falls inside the stated range.
By their numbers in this assay, from the lowest: compounds 3 and 4 (each within the scatter of the next); then compound 2; then compound 1.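

In this assay a second methyl, para to the methyl group already on the ring, is accommodated: a 1.8-fold higher number from compound 3 to compound 4 (0.27 log units; within the scatter) means that 2,5-dimethylphenyl and 2-methylphenyl cannot be told apart at this position. The 2,5-dimethylphenyl group also keeps an advantage over 4-methylphenyl, with a 3.5-fold lower number from compound 2 to compound 4 (0.55 log units; beyond the scatter) as the step beyond the scatter. Nothing available explains either step. On these data alone, what a methoxy group, a chlorine atom or an amine would give at this place stays open, and a methyl at this place without the first one is also unresolved.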